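This account rests on a few compounds, and the source may have more. Where it says the series, first, only, none or still open, it means among the compounds named here.

In a physicochemical assay for lipophilicity, using the shake flask method, in phosphate buffer, measured as octanol-water partition, at pH 7.4 (a higher number here means a more lipophilic compound, a lower number a more polar compound), compound 3 `N#CC[C@]1(n2cc(-c3nc(-c4cc[nH]n4)cn4nccc34)cn2)C[C@H](C#N)C1` gives 1.7. Compound 2 `N#CC[C@]1(n2cc(-c3nc(-c4cn[nH]c4)cn4nccc34)cn2)C[C@H](C#N)C1` gives 1.7, and compound 1 `Cn1ccc(-c2cn3nccc3c(-c3cnn([C@]4(CC#N)C[C@H](C#N)C4)c3)n2)n1` gives 1.6. The three numbers lie within the scatter of one another, and compound 3 stands level with compound 2.

Still to be measured is compound 4 `N#CC[C@]1(n2cc(-c3nc(-c4cc[nH]n4)cn4nccc34)cn2)C[C@@H](C#N)C1`. Its difference from compound 3 lies in configuration alone: the two compounds have the same atoms and bonds and differ only in configuration as drawn: 2 of 2 stereo elements differ (all stereocentres are inverted: mirror images); a stereocentre at a saturated ring carbon is drawn r in compound 3 and s in compound 4; a stereocentre at a saturated ring carbon is drawn r in compound 3 and s in compound 4. Nothing leaves and nothing enters.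

Among the compounds with values here, only one measured step changes a single place, no change at the digits printed from compound 2 to compound 3 (within the scatter), with 1H-pyrazol-3-yl in place of 1H-pyrazol-4-yl on an aromatic carbon. That step concerns a group rather than configuration, so it bears on this change only indirectly. Within the data shown here, no measured pair differs in configuration alone, so the data give no direct guide to this change.

Starting from compound 3 at 1.7, no step beyond the scatter is expected in this assay, and no direction can be named. The expected step is no change at the digits printed from compound 3 to compound 4 (within the scatter). For compound 4 the estimated value is 1.7, with an expected range from 1.4 to 2.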

Compound 4, distribution coefficient: 1.7
Beside the measured number, compound 4's estimate shows no gap at the digits printed, and the stated range covers the measured number.
By their numbers in this assay, from the lowest: compounds 1, 2, 3 and 4 (each within the scatter of the next).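

Within the data shown here, the first pair to differ in configuration alone gives, in this assay, no change at the digits printed from compound 3 to compound 4 (within the scatter), so inverting both stereocentres at the saturated ring carbons leaves the number in place at this position. With nothing leaving and nothing entering, this step offers no group to which any shift could be tied, and the reading rests on one structural fact: the fact that compounds 3 and 4 differ only in the configuration as drawn Compound 4 also supplies a second step, hydrogen in place of methyl on an aromatic nitrogen, which reads a number 0.10 log units higher from compound 1 to compound 4 (within the scatter), so in this assay this change of group, like the move from 1H-pyrazol-4-yl to 1H-pyrazol-3-yl, stays inside the usual spread of repeated measurements.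

All of this rests on single pairs, and the four compounds show no step beyond the scatter, so they say nothing about what would move the number on this scaffold. From the compounds shown here alone, it remains open whether a carboxylic acid or an amine in place of the pyrazolyl group would shift the number in this assay, and whether inverting both stereocentres would still leave such a compound unchanged.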